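Furan in place of chlorophenyl on the shared core

The source may report more compounds than this note shows. Statements on the series, on what has been measured and on what is new or still open speak of the compounds shown alone.

Compounds measured so far:
compound 1 `O=C(O)CCc1ccc(OCc2nc(-c3ccccc3Cl)no2)cc1` gives 1200 nM
compound 2 `O=C(O)CCc1ccc(OCc2nc(-c3ccc(Cl)cc3)no2)cc1` gives 540 nM

Both compounds were tested in a functional assay on CHO cells for agonist activity at Free fatty acid receptor 1 (Homo sapiens), read by FLIPR and calcium flux, in the presence of a further agent that is not named here; on this read-out higher numbers stand for an effect only at larger amounts of compound and lower numbers for an effect already at smaller amounts. Compound 2 stands at the lowest of the two numbers; the nearest is compound 1, and the step of a 2.2-fold lower number from compound 1 to compound 2 (0.35 log units; beyond the scatter) lies beyond the scatter.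

Compound 3 `O=C(O)CCc1ccc(OCc2nc(-c3ccco3)no2)cc1` has not yet been measured. It differs from compound 2 in one place: furan-2-yl in place of 4-chlorophenyl on an aromatic carbon. Going by the values given here, the only step known so far, a 2.2-fold lower number from compound 1 to compound 2 (0.35 log units; beyond the scatter), moves a chlorine from one position of the phenyl ring to another and says nothing about exchanging the whole ring for furan-2-yl. Among the compounds with values here, no measured step therefore bears directly on this change. Without such guidance, compound 3 is expected to land near compound 2 or somewhat weaker, with a wide range: the estimate for compound 3 in this assay is 1500 nM, between 500 nM and 5000 nM, which corresponds to an expected step of a 2.8-fold higher number from compound 2 to compound 3 (0.44 log units; beyond the scatter).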

Compound 3, half-maximal effective concentration: > 100000 nM
Compound 3 ended at the assay's limit; the forecaster's own chance of this, stated with the estimate: 15%; middle value at least 66-fold (1.82 log units) away from the limit.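

In this assay compound 3 ends at a limit of the assay, not at a number: the limit of > 100000 nM in this assay, at which 1 of the 3 values shown sits.

Moving the chlorine around the phenyl ring had changed little, but replacing the whole ring has a far larger effect, with an at least 180-fold higher number from compound 2 to compound 3 (2.26 log units; beyond the scatter) and an at least 83-fold higher number from compound 1 to compound 3 (1.92 log units; beyond the scatter). Among these three compounds, then, this position on the shared core accepts either chlorophenyl group with a measurable result, whereas furan-2-yl gives none within the range of the assay.

The exchange alters several things at once: the ring size, the ring oxygen and the loss of the chlorine, and the compounds shown cannot separate these. On these data alone, whether a plain phenyl or a thiophen-2-yl group here would behave like the chlorophenyl compounds or like compound 3 remains open.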